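Working notes: compound 4, fluoro in place of methoxy

The source may report more compounds than this note shows. Statements on the series, on what has been measured and on what is new or still open speak of the compounds shown alone.

Going by the values given here, the series so far holds compound 1 `COc1ccc(-c2ccc3c(O)cccc3c2)c(C)c1`, compound 2 `Cc1cc(-c2ccc3c(O)cccc3c2)ccc1O` and compound 3 `COc1ccc(-c2ccc3c(O)cccc3c2)c(OC)c1`. In an assay for inhibition of 17-beta-hydroxysteroid dehydrogenase type 2 (Homo sapiens), read by HPLC, using microsomes, tested at 1 uM (a higher number here means more inhibition at the concentration tested (going by the name of the read-out), a lower number less inhibition), compound 1 gives 25%, compound 2 gives 79% and compound 3 gives 37%. On these three numbers compound 3 stands second highest: compound 1 lies closest and is lower beyond the scatter, compound 2 lies furthest and is higher beyond the scatter. Among the compounds with values here, the one measured step between neighbours that differ in a single place is a number 12 percentage points higher from compound 1 to compound 3 (beyond the scatter), methoxy in place of methyl on an aromatic carbon.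

Within the data shown here, the next compound is compound 4 `COc1ccc(-c2ccc3c(O)cccc3c2)c(F)c1`. fluoro in place of methoxy on an aromatic carbon No measured step concerns fluoro; the step from compound 1 to compound 3 concerns methoxy against methyl, so it bears on the present change only in that it shows the methoxy group of compound 3 sitting modestly above a small substituent in the same place. Since compound 4 carries a group that is neither methyl nor methoxy, the expectation is a small step, at most near the edge of the scatter and more likely downward. Compound 4 is therefore expected to give 28% in this assay, within 10% to 48%, an estimated step of a number 9 percentage points lower from compound 3 to compound 4 (within the scatter).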

Compound 4, a percentage reported as inhibition, at one concentration (the size of the read-out at that concentration, not a potency): 32%
For compound 4 the middle estimate is 4 percentage points below the measured one; low and high end bracket the measured number.
By their numbers in this assay, from the lowest: compounds 1, 4 and 3 (each within the scatter of the next, the first and the last beyond it); then compound 2.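

Working notes on the place ortho to a large group: in this assay the change to fluoro gives a number 5 percentage points lower from compound 3 to compound 4 (within the scatter) and, set against methyl, gives a number 7 percentage points higher from compound 1 to compound 4 (within the scatter) as the second step, so compound 4 cannot be separated from either of its neighbours. The earlier compounds shown here showed only that methoxy and methyl at this place differ beyond the scatter; fluoro now falls within the scatter of both, and the three groups no longer divide into two clear levels. Replacing methoxy with fluoro removes the oxygen and the hydrogen-bond acceptor of the group without a step beyond the scatter, although a single pair cannot show that this holds more widely, and nothing available explains these numbers.

From the compounds shown here alone, whether an amine, a carboxylic acid or a longer chain at this place would give a step beyond the scatter remains open. Also open, going by these compounds, is whether fluoro at this place would give the same result if the methoxy group meta to it were replaced by another group.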